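The compounds below may be only part of what the source reports. "The series", "measured", "known", "first", "only" and "open" are said of these compounds alone.

Measured so far in a functional assay on VCaP cells (Homo sapiens) for antiproliferative activity, read by propidium iodide staining, with a stated time of 96 h; on this read-out higher numbers stand for weaker inhibition and lower numbers for stronger inhibition:
- compound 1 `CC(O)(CS(=O)(=O)c1ccc(F)cc1)C(=O)Nc1cccc(S(F)(F)(F)(F)F)c1` gives 37900 nM
- compound 2 `CC(O)(CS(=O)(=O)c1ccccc1C(F)(F)F)C(=O)Nc1cccc(S(F)(F)(F)(F)F)c1` gives 40800 nM
- compound 3 `CC(O)(CS(=O)(=O)c1ccc(OC(F)(F)F)cc1)C(=O)Nc1cccc(S(F)(F)(F)(F)F)c1` gives 15100 nM

Compound 3 has the lowest number of the three, and its distance from each of the others lies beyond the scatter (a 2.5-fold lower number from compound 1 to compound 3 (0.40 log units; beyond the scatter); a 2.7-fold lower number from compound 2 to compound 3 (0.43 log units; beyond the scatter)). Compound 4 `CC(O)(CS(=O)(=O)c1cccc(OC(F)(F)F)c1)C(=O)Nc1cccc(S(F)(F)(F)(F)F)c1` keeps the same group but moves it, with 3-(trifluoromethoxy)phenyl in place of 4-(trifluoromethoxy)phenyl on a sulfonyl sulfur. For the measured compounds named here, no measured step isolates such a move. The closest evidence is that swapping the aryl group on the sulfonyl sulfur has so far produced only small steps: one stayed within the scatter (a 1.1-fold higher number from compound 1 to compound 2 (0.03 log units; within the scatter)), and the two that reach compound 3 were modest. A small rise in the number in this assay is therefore expected, probably not beyond the scatter. The expected step is (a 1.5-fold higher number from compound 3 to compound 4 (0.16 log units; within the scatter)) by this estimate. For compound 4 the estimated value is (22000 nM), with an expected range from 9000 nM to 45000 nM in the same read-out.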

Compound 4, half-maximal inhibitory concentration: 20200 nM
Estimate against measurement, compound 4: 1.1-fold (0.04 log units) above, and the stated range covers the measured number.
By their numbers in this assay, from the lowest: compounds 3, 4, 1 and 2 (each within the scatter of the next, the first and the last beyond it).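

In this assay, moving the trifluoromethoxy group, with 3-(trifluoromethoxy)phenyl in place of 4-(trifluoromethoxy)phenyl on the sulfonyl sulfur, leaves the two placements not told apart (a 1.3-fold higher number from compound 3 to compound 4 (0.13 log units; within the scatter)). The moved group keeps a separation beyond the scatter from the 2-(trifluoromethyl)phenyl group (a 2.0-fold lower number from compound 2 to compound 4 (0.31 log units; beyond the scatter)), but not from the 4-fluorophenyl group (a 1.9-fold lower number from compound 1 to compound 4 (0.27 log units; within the scatter)), so only part of the margin seen with the 4-(trifluoromethoxy)phenyl group survives the move. Nothing available explains these small differences.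

On these data alone, it remains open whether any group on the sulfonyl sulfur can bring the number well under that of compound 3 at (15100 nM). Also open, as far as these compounds go, is how an aryl ring carrying an amine or a carboxylic acid, or a saturated chain in place of the ring, would read in this assay.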